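The source may report more compounds than this note shows. Statements on the series, on what has been measured and on what is new or still open speak of the compounds shown alone.

Compound 1 `O=C(Nc1cccc(-c2ccsc2)c1)C(Cl)Cl` gives > 50000 nM in a functional assay on NCI-H460 cells (Homo sapiens) for cytotoxicity, read by MTT assay, with a stated time of 68 h; on this read-out lower numbers stand for stronger inhibition and higher numbers for weaker inhibition; this is a limit of the assay, not a number.
Compound 2 `O=C(Nc1cccc(-c2cccc(NC(=O)C(Cl)Cl)c2)c1)C(Cl)Cl` gives > 50000 nM in this assay; this too is a limit.
Compound 3 `O=C(Nc1cccc(-c2ccccn2)c1)C(Cl)Cl` gives > 50000 nM in this assay; again a limit.

Compound 2 therefore stands nowhere on a scale of numbers: every value shown is a limit, and the limit of > 50000 nM in this assay, at which 3 of the 3 values shown sit, describes all three. Compound 4 `O=C(Nc1cccc(-c2cccc(Cl)c2)c1)C(Cl)Cl` has not yet been measured. It differs from compound 2 in one place, (chloro in place of ((dichloromethyl)carbonyl)amino on an aromatic carbon), on an aromatic carbon of a six-membered aromatic ring of carbon only. Within the data shown here, the only measured step between single-change neighbours is a step that the two limits leave unreadable from compound 1 to compound 3, and its size cannot be read because both ends are limits. Among the measured compounds shown here, no measured step bears on an exchange of this kind, so no direction can be taken from the data. With every neighbour sitting at the limit, compound 4 is expected to behave alike, and its expected step is a number no higher from compound 2 to compound 4 (the limit leaves the size open). The estimate for compound 4 in this assay is 50000 nM, within 10000 nM to 200000 nM, most likely reported only as a limit.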

Compound 4, half-maximal inhibitory concentration: > 50000 nM
Compound 4: only a limit was reported; the forecaster's own chance of this, stated with the estimate: 75%; the middle value sits exactly at the limit.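

Among these compounds, compound 2 and compound 4 both give a limit of the assay rather than a number, so no step between them can be read: the limit of > 50000 nM in this assay, at which 4 of the 4 values shown sit.
The compounds shown leave open how much any of them inhibits in this assay, and which change to the shared core would give a readable number.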